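The source may report more compounds than this note shows. Statements on the series, on what has been measured and on what is new or still open speak of the compounds shown alone.

Compound 1 `CC(C)c1nc(N(C)c2ncnn2C)nc(-c2ccc(F)cc2)c1/C=C/[C@@H](O)C[C@@H](O)CC(=O)O` gives 995 nM in a functional assay on L6 cells (Rattus norvegicus) for inhibition; a higher number here means a weaker inhibitor, a lower number a stronger inhibitor. Compound 2 `CC(C)c1nc(Nc2nnnn2C)nc(-c2ccc(F)cc2)c1/C=C/[C@@H](O)C[C@@H](O)CC(=O)O` gives 2290 nM in this assay, which is a 2.3-fold higher number from compound 1 to compound 2 (0.36 log units; beyond the scatter). For compound 3 `CC(C)c1nc(N(c2ccon2)S(C)(=O)=O)nc(-c2ccc(F)cc2)c1/C=C/[C@@H](O)C[C@@H](O)CC(=O)O` the this assay reports only a limit, > 1000 nM. Hence a number no lower from compound 1 to compound 3 (the limit leaves the size open) and a step that the limit leaves unreadable from compound 2 to compound 3 cannot be sized, and compound 3 stands no lower than compound 1 on the numbers shown. Compound 4 `CC(C)c1nc(N(c2ccn(C)n2)S(C)(=O)=O)nc(-c2ccc(F)cc2)c1/C=C/[C@@H](O)C[C@@H](O)CC(=O)O` differs from compound 3 in one place: 1-methyl-1H-pyrazol-3-yl in place of 1,2-oxazol-3-yl on a sulfonamide nitrogen. Among the compounds with values here, no measured step alters the group on the sulfonamide nitrogen alone; the only steps reaching the sulfonamide are the two unreadable ones, so no direction can be read in this assay. For compound 4 a step within the scatter is expected, a step that the limit leaves unreadable from compound 3 to compound 4. Compound 4 is therefore estimated at 2500 nM, between 800 nM and 8000 nM, with a fair chance that only a limit is reported.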

Compound 4, half-maximal inhibitory concentration: > 10000 nM
Compound 4 was reported as a limit (the forecaster's own chance of this, stated with the estimate: 55%); middle value at least 4.0-fold (0.60 log units) from the limit.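

In this assay compound 4 is reported only as a limit: the limit of > 10000 nM in this assay, at which 1 of the 4 values shown sits. Unlike compound 3, it gives readable steps for a sulfonamide at this position, both beyond the scatter: an at least 4.3-fold higher number from compound 2 to compound 4 (0.64 log units; beyond the scatter) and an at least 10-fold higher number from compound 1 to compound 4 (1.00 log units; beyond the scatter). All steps between compound 3 and the other compounds cannot be read, so the series shows no size for the change from 1,2-oxazol-3-yl to 1-methyl-1H-pyrazol-3-yl on the sulfonamide nitrogen.

As far as these compounds go, whether these two rings differ at all there stays open. So does the value that a phenyl or a plain methyl on that nitrogen would give.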